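Compound 2 and the loss of one methyl

This account rests on a few compounds, and the source may have more. Where it says the series, first, only, none or still open, it means among the compounds named here.

compound 1 `Cc1cc(C)c2c(O)cc(-c3ccc(Cl)cc3)nc2n1` gives 19500 nM
compound 2 `COc1cccc(-c2cc(O)c3c(C)cc(C)nc3n2)c1` gives 646 nM

In a functional assay on cells (Tumor Cell line, Homo sapiens) for cytotoxicity (a lower number here means a stronger inhibitor of growth, a higher number a weaker inhibitor of growth), compound 2 has the lower number of the two, beyond the scatter from compound 1. Compound 3 `COc1cccc(-c2cc(O)c3c(C)ccnc3n2)c1` differs from compound 2 in one place (hydrogen in place of methyl on an aromatic carbon), with hydrogen in place of methyl on an aromatic carbon, next to the ring nitrogen. For the measured compounds named here, no measured pair shows this change alone, so only a modest weakening is expected, possibly none beyond the scatter. The estimated change is a 1.4-fold higher number from compound 2 to compound 3 (0.14 log units; within the scatter) in this reading. For compound 3 the expected value is 900 nM with an estimated range from 250 nM to 4000 nM in this assay.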

Compound 3, concentration for 50% growth inhibition: 58.9 nM
Compound 3: the middle estimate sits 15-fold (1.18 log units) above what was measured; measured number below the stated range.
By their numbers in this assay, from the lowest: compound 3; then compound 2; then compound 1.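

In this assay hydrogen in place of methyl on an aromatic carbon, next to the ring nitrogen, gives an 11-fold lower number from compound 2 to compound 3 (1.04 log units; beyond the scatter) and shows that this single position strongly affects growth inhibition. On this core, the methyl group there goes with a weaker inhibitor than hydrogen does, so the smallest possible edit produced a large change. No measurement shown here explains this gain. As far as these compounds go, whether an ethyl group, a chlorine atom or an amine at this position would match hydrogen remains open. Also open, from the compounds shown here alone, is whether the same change would help when the methoxyphenyl group is replaced by the chlorophenyl group of compound 1.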